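This account rests on a few compounds, and the source may have more. Where it says the series, first, only, none or still open, it means among the compounds named here.

Compound 1 `COc1cccc(C(O)CCn2nc3c(Br)c(Br)c(Br)c(Br)c3n2)c1` and compound 2 `OC(CCn1nc2c(Br)c(Br)c(Br)c(Br)c2n1)c1ccc(Br)cc1` were measured in a functional assay on MCF7 cells (Homo sapiens) for antiproliferative activity, read by MTT assay, with a stated time of 48 h, tested at 12.5 uM; a lower number here means a stronger effect, a higher number a weaker effect of the compound at the concentration tested. Compound 1 gives 97% and compound 2 gives 107%. Compound 1 thus shows the lowest of the two numbers, with compound 2 nearest, a number 10 percentage points higher from compound 1 to compound 2 (within the scatter). The unmeasured compound 3 `OC(CCn1nc2c(Br)c(Br)c(Br)c(Br)c2n1)c1ccc(Cl)cc1` differs from compound 1 by 4-chlorophenyl in place of 3-methoxyphenyl on a saturated chain carbon bound to an oxygen on a saturated carbon and a saturated chain carbon. Among the compounds with values here, the only step that bears on this change is that from compound 1 to compound 2, where a 4-bromophenyl replaced the 3-methoxyphenyl, and it stayed within the scatter. Compound 3 is therefore expected to show a number 3 percentage points higher from compound 1 to compound 3 (within the scatter), no step beyond the scatter, with an estimate of 100% ranging from 88% to 112%.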

Compound 3, a percentage reported as activity, at one concentration (the size of the read-out at that concentration, not a potency): 100%
Estimate against measurement, compound 3: no gap at the digits printed; measured number inside the range.
By their numbers in this assay, from the lowest: compounds 1, 3 and 2 (each within the scatter of the next).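

Changing 3-methoxyphenyl to 4-chlorophenyl at this position gives a number 3 percentage points higher from compound 1 to compound 3 (within the scatter) and, on an aromatic carbon, chloro in place of bromo gives a number 7 percentage points lower from compound 2 to compound 3 (within the scatter) as the two new steps. Within the data shown here, the exchange of one halogen for the other thus joins the aryl change in staying within the scatter, and no step among the three compounds goes beyond it. No measurement at hand accounts for this. Going by these compounds, whether an amine or a carboxylic acid on the phenyl ring would move the number remains open. So does the effect of a longer chain.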